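A Dimethylcarbamoyl Exchange in Place of Isopropoxy

This account rests on a few compounds, and the source may have more. Where it says the series, first, only, none or still open, it means among the compounds named here.

In a functional assay on SiHa cells (Homo sapiens) for antiproliferative activity, read by CCK-8 assay, with a stated time of 72 h (on this read-out higher numbers stand for weaker inhibition and lower numbers for stronger inhibition), compound 1 (`CCOc1ccc(-c2cncnc2-c2cc(OC)c(OC)c(OC)c2)cc1`) gives 640 nM while compound 2 (`COc1cc(-c2ncncc2-c2ccc(OCC(F)(F)F)cc2)cc(OC)c1OC`) gives 33300 nM and compound 3 (`COc1cc(-c2ncncc2-c2ccc(OC(C)C)cc2)cc(OC)c1OC`) gives 9970 nM (second highest of the three numbers). Compound 4 (`COc1cc(-c2ncncc2-c2ccc(C(=O)N(C)C)cc2)cc(OC)c1OC`) carries dimethylcarbamoyl in place of isopropoxy on an aromatic carbon. For the measured compounds named here, no measured step makes this exchange. Going by the values given here, three steps bear on it indirectly, since each alters the chain on the oxygen at this place: two are large (a 52-fold higher number from compound 1 to compound 2 (1.72 log units; beyond the scatter) and a 16-fold higher number from compound 1 to compound 3 (1.19 log units; beyond the scatter)) and one is modest (a 3.3-fold lower number from compound 2 to compound 3 (0.52 log units; beyond the scatter)). They give no direction for dimethylcarbamoyl, so no step beyond the scatter is expected, with wide uncertainty. The expected change is a 1.2-fold higher number from compound 3 to compound 4 (0.08 log units; within the scatter). For compound 4 the estimated value is 12000 nM (expected range 2000 nM to 50000 nM).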

Compound 4, half-maximal inhibitory concentration: 20200 nM
Compound 4: the middle estimate sits 1.7-fold (0.23 log units) below what was measured; measured number inside the range.
By their numbers in this assay, from the lowest: compound 1; then compound 3; then compounds 4 and 2 (each within the scatter of the next).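

For the compounds shown here, the first group at this place that is not an alkoxy chain, dimethylcarbamoyl, does not bring back the activity of the ethoxy compound in this assay, with a 32-fold higher number from compound 1 to compound 4 (1.50 log units; beyond the scatter). Measured against the other two chains, it gives a 2.0-fold higher number from compound 3 to compound 4 (0.31 log units; beyond the scatter) and a 1.6-fold lower number from compound 2 to compound 4 (0.22 log units; within the scatter). Ethoxy therefore keeps the lowest number of the four compounds, and a change away from the alkoxy chains has not improved on it. Nothing available explains these differences. From the compounds shown here alone, whether methoxy, a propoxy chain, or an amine at this place would come closer to compound 1 stays open.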